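The source may hold more compounds than are shown below. What is called first, only, known or untested is meant among the compounds shown, and "the series" means these compounds.

Compound 2 `O=C(Nc1ccc(Cl)c(-c2nnc3c(Cl)cccn23)c1)c1cccnc1` belongs to a small set of amides built on one shared core and tested in a functional assay on T47D cells (Homo sapiens) for antiproliferative activity, read by MTT assay, with a stated time of 72 h; a lower number here means a stronger inhibitor, a higher number a weaker inhibitor. Its only companion so far is compound 1 `O=C(Nc1ccc(Cl)c(-c2nnc3c(Cl)cccn23)c1)c1ccc(F)cc1Cl`. In this assay compound 1 gives > 100000 nM, which is a limit of the assay and not a number. In this assay compound 2 gives > 100000 nM, likewise a limit and not a number. The step that the two limits leave unreadable from compound 1 to compound 2 is therefore unreadable, since both values sit at the limit of > 100000 nM in this assay, at which 2 of the 2 values shown sit, and compound 2 stands exactly where compound 1 stands: at the upper limit, with no measurable activity shown.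

Compound 3 `O=C(Nc1ccc(Cl)c(-c2nnc3c(Cl)cccn23)c1)c1cccc(Cl)c1` is the next compound to be measured in this assay. It differs from compound 2 by 3-chlorophenyl in place of pyridin-3-yl on a carbonyl carbon. For the measured compounds named here, the one measured step that bears on this, the step from compound 1 to compound 2, has no readable size, so there is no measured guide to how a carbocyclic ring in place of the pyridine ring would move the value. Both measured compounds show no activity at the limit. Compound 3 is therefore expected to give 150000 nM, with a range from 40000 nM to 600000 nM. The step that the limit leaves unreadable from compound 2 to compound 3 that this estimate means is expected to be none beyond the scatter.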

Compound 3, half-maximal inhibitory concentration: 30200 nM
Beside the measured number, compound 3's estimate is 5.0-fold (0.70 log units) above it; measured number outside the range, below it.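

In this assay compound 3 is the first of these amides to give a readable number, which shows that the group on the carbonyl carbon can decide whether any activity appears at all, something the earlier compounds could not show: the limit of > 100000 nM in this assay, at which 2 of the 3 values shown sit.

Putting 3-chlorophenyl in place of pyridin-3-yl gives an at least 3.3-fold lower number from compound 2 to compound 3 (0.51 log units; beyond the scatter), and putting it in place of 2-chloro-4-fluorophenyl gives an at least 3.3-fold lower number from compound 1 to compound 3 (0.51 log units; beyond the scatter); each size is only a bound, set by a limit of the assay and not by a number. A chlorine on a ring of carbon only is not enough by itself, for compound 1 also carries one and its value remains a limit of the assay.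

The three compounds leave open whether the gain in compound 3 rests on the chlorine or on the ring of carbon only, a question that a plain phenyl group would help to separate. They also leave open how a methoxy group, a trifluoromethyl group or an amine on that ring would read in this assay, and what the two chlorines of the shared core contribute.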